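Swapping the aryl group on compound 2's fused core

The source may report more compounds than this note shows. Statements on the series, on what has been measured and on what is new or still open speak of the compounds shown alone.

Of the compounds shown here, three of one family have been measured in a physicochemical assay for acid dissociation. Compound 1 `COc1ccccc1Oc1ccc2c(NCCCNCc3ccco3)ccnc2c1` gives 9.28. Compound 3 `COc1ccc(F)cc1CNCCCNc1ccnc2cc(Oc3ccc(C(C)(C)C)cc3)ccc12` gives 9.28. Compound 2 `COc1cccc(CNCCCNc2ccnc3cc(-c4ccc(C(F)(F)F)cc4)ccc23)c1O` gives 9.47, a number that sits within the usual scatter of both compound 1 and compound 3, so the three cannot be told apart on this read-out. Compound 4 `COc1cccc(CNCCCNc2ccnc3cc(Cc4ccc(F)cc4)ccc23)c1O` has not yet been measured; it differs from compound 2 by 4-fluorobenzyl in place of 4-(trifluoromethyl)phenyl on an aromatic carbon. For the measured compounds named here, no step between measured compounds is known, and compound 1, compound 2 and compound 3 all carry different groups at that aromatic carbon yet fall within scatter of each other, so the step from compound 2 to compound 4 is expected to be a number 0.12 log units lower from compound 2 to compound 4 (within the scatter), nothing beyond the scatter. For compound 4 the expected value is 9.35, between 9 and 9.7.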

Compound 4, acid dissociation constant: 9.47
For compound 4 the middle estimate is 0.12 log units below the measured one; the measured number falls inside the stated range.
By their numbers in this assay, from the lowest: compounds 1, 3, 2 and 4 (each within the scatter of the next).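

In this assay, for the compounds shown here, putting 4-fluorobenzyl in place of 4-(trifluoromethyl)phenyl gives no change at the digits printed from compound 2 to compound 4 (within the scatter), the first comparison in which only this aromatic carbon's group differs. This exchange, with the rest of the molecule held constant, leaves the read-out indistinguishable. No measurement shown here gives a reason for this result.

Both groups have one six-membered aromatic ring of carbon only and no hydrogen-bond donors or acceptors. The compounds shown therefore leave open what an amine or a carboxylic acid at this carbon would do to the number.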